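The source may report more compounds than this note shows. Statements on the series, on what has been measured and on what is new or still open speak of the compounds shown alone.

Compound 1 `O=C(COc1ccc(/C=C2\SC(=O)NC2=O)cc1)Nc1cccc([N+](=O)[O-])c1`: in a functional assay on KB cells (Homo sapiens) for inhibition (on this read-out higher numbers stand for weaker inhibition of growth and lower numbers for stronger inhibition of growth), compound 1 gives > 100000 nM, a limit of the assay.
Compound 2 `Cc1cc(Br)ccc1NC(=O)COc1ccc(/C=C2\SC(=O)NC2=O)cc1`: in this assay compound 2 gives > 100000 nM, likewise a limit.

Compound 2 thus stands only at a limit in this assay, and both measured values sit there (the limit of > 100000 nM in this assay, at which 2 of the 2 values shown sit). Compound 3 `O=C(COc1ccc(/C=C2\SC(=O)NC2=O)cc1)Nc1c(F)cc(Br)cc1F` differs from compound 2 by 4-bromo-2,6-difluorophenyl in place of 4-bromo-2-methylphenyl on an amide-type nitrogen. Within the data shown here, the single measured step, a step that the two limits leave unreadable from compound 1 to compound 2, cannot be read; both of its ends are limits. Among the measured compounds shown here, no size of step in this assay can therefore be expected from the data, and compound 3 is expected to sit again at a limit. Compound 3 is estimated at 150000 nM, between 60000 nM and 500000 nM. The implied step, a step that the limit leaves unreadable from compound 2 to compound 3, is expected to stay within the scatter.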

Compound 3, concentration for 50% growth inhibition: > 100000 nM
Compound 3: no number, only a limit; the forecaster's own chance of this, stated with the estimate: 85%; the middle value does not contradict the limit.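

In this assay, among these compounds, compound 3 gives > 100000 nM, a limit, so no step among compound 1, compound 2 and compound 3 can be read: the limit of > 100000 nM in this assay, at which 3 of the 3 values shown sit. The compounds shown leave open how strongly each inhibits growth, and whether the group on the amide-type nitrogen matters at all.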